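The source may report more compounds than this note shows. Statements on the series, on what has been measured and on what is new or still open speak of the compounds shown alone.

Measured in a physicochemical assay for lipophilicity; on this read-out higher numbers stand for higher lipophilicity and lower numbers for lower lipophilicity
- compound 1 `CCCCS(=O)(=O)c1ccc(O)c(C(=O)Nc2ccc(Br)cc2)c1` gives 4.12
- compound 2 `CCCCCCCCCCS(=O)(=O)c1ccc(O)c(C(=O)Nc2ccc(Br)cc2)c1` gives 7.36
- compound 3 `CCCCCCCCCCCCS(=O)(=O)c1ccc(O)c(C(=O)Nc2ccc(Br)cc2)c1` gives 8.44

Compound 2 is the second highest of these three numbers, well above compound 1 and clearly under compound 3. Compound 4 `CCCCCCCCCCS(=O)(=O)c1ccc(O)c(C(=O)Nc2ccc(C(F)(F)F)cc2)c1` differs from compound 2 in one place: trifluoromethyl in place of bromo on an aromatic carbon while the chain on the sulfonyl sulfur stays the same.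

All three measured steps are large, but all are changes to that chain: hexyl in place of hydrogen (a number 3.24 log units higher from compound 1 to compound 2 (beyond the scatter)), octyl in place of hydrogen (a number 4.32 log units higher from compound 1 to compound 3 (beyond the scatter)) and ethyl in place of hydrogen (a number 1.08 log units higher from compound 2 to compound 3 (beyond the scatter)). Going by the values given here, none of them tests a swap on the aromatic carbon, so their size does not carry over, and no measured step covers this change directly. The starting point is therefore compound 2 (7.36) in this assay with the chain unchanged. The expected change is none beyond the scatter (a number 0.04 log units higher from compound 2 to compound 4 (within the scatter)). Compound 4 is estimated at 7.4 with an expected range (7 to 7.8).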

Compound 4, partition coefficient: 7.38
Estimate against measurement, compound 4: 0.02 log units above; low and high end bracket the measured number.
By their numbers in this assay, from the lowest: compound 1; then compounds 2 and 4 (each within the scatter of the next); then compound 3.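

Going by these compounds alone, this is the first reading at the aromatic carbon, rather than on the chain on the sulfonyl sulfur. In this assay, trifluoromethyl in place of bromo gives a number 0.02 log units higher from compound 2 to compound 4 (within the scatter), so the two compounds cannot be told apart here, even though 4 heavy atoms enter where 1 heavy atom leaves. At this position, with this chain, the swap does not produce anything like the large differences seen when the chain changes, though no information shown here accounts for the match between the two groups.

As far as these compounds go, whether the match also holds with the shorter chain of compound 1 or the longer chain of compound 3 remains open. So does what a carboxylic acid or an amine on this same aromatic carbon would do to the number.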